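The source may hold more compounds than are shown below. What is called first, only, known or untested is meant among the compounds shown, and "the series" means these compounds.

Compound 1 `CC(=O)Nc1ccc(CN2CCC=C(CCC(=O)NO)C2=O)cc1`: "not determined" (no result reported) in a functional assay on HCT-15 cells (Homo sapiens) for inhibition, read by sulforhodamine B assay; on this read-out higher numbers stand for weaker inhibition of growth and lower numbers for stronger inhibition of growth.
Compound 2 `COc1ccc(CN2CCC=C(CCC(=O)NO)C2=O)cc1`: 6890 nM.
Compound 3 `O=C(CCC1=CCCN(Cc2ccc([N+](=O)[O-])cc2)C1=O)NO`: > 10000 nM, which is a limit, not a number.

Compound 3 is reported only as a limit (the limit of > 10000 nM in this assay, at which 1 of the 3 values shown sits), so where it truly stands among the numbers is not known. Compound 4 `Cc1ccc(CN2CCC=C(CCC(=O)NO)C2=O)cc1` differs from it by one change: methyl in place of nitro on an aromatic carbon. Among the compounds with values here, the only measured step, an at least 1.4-fold higher number from compound 2 to compound 3 (0.16 log units; that floor lies within the scatter), swapped methoxy for nitro, and its floor lies within the scatter. Within the data shown here, no step compares methyl with either nitro or methoxy, so the direction is uncertain. For compound 4 the expected step is an at least 1.4-fold lower number from compound 3 to compound 4 (0.15 log units; that floor lies within the scatter), toward stronger inhibition, because compound 2 gives 6890 nM and methyl is taken to sit closer to methoxy than to nitro. The estimate for compound 4 is 7000 nM, between 2500 nM and 20000 nM.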

Compound 4, concentration for 50% growth inhibition: 8510 nM
For compound 4 the middle estimate is 1.2-fold (0.08 log units) below the measured one; measured number inside the range.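

Para to a large group, methyl can now be set against methoxy on real numbers, and in this assay the two cannot be told apart: a 1.2-fold higher number from compound 2 to compound 4 (0.09 log units; within the scatter). Against nitro the change shows only a floor that lies within the scatter, so no difference between methyl and nitro is established: an at least 1.1-fold lower number from compound 3 to compound 4 (0.07 log units; that floor lies within the scatter). Compound 3 remains a limit, not a number: the limit of > 10000 nM in this assay, at which 1 of the 4 values shown sits. Still open, as far as these compounds go, is whether any group at this position moves the number beyond the scatter. An amine, a carboxylic acid or a chlorine atom there would test this.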